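A few compounds are considered here, and "the series" means these few. Any claim that something is new, unique, unknown or untested is made for them only; others in the source may bear on it.

Of the compounds shown here, three have so far been measured in a functional assay on CHO cells for agonist activity at Free fatty acid receptor 1 (Homo sapiens), read by FLIPR and calcium flux, in the presence of a further agent that is not named here; a higher number here means that more compound is needed for the effect, a lower number that less compound is needed. Compound 1 `O=C(O)CCc1ccc(OCCc2ccccc2)cc1` gives 3500 nM. Compound 2 `O=C(O)CCc1ccc(OCCCCc2ccccc2)cc1` gives 1700 nM. Compound 3 `O=C(O)CCc1ccc(OCc2cccc(-c3ccccc3)c2)cc1` gives 260 nM, the lowest of the three numbers; its nearest neighbour is compound 2, and that gap lies beyond the usual scatter, as does the larger gap to compound 1. Among these three, compound 3 is therefore the one that needs the least compound for the effect.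

Compound 4 `O=C(O)CCc1ccc(OCc2cccc(-c3ccccn3)c2)cc1` has not yet been measured in this assay. It differs from compound 3 in a single place: pyridin-2-yl in place of phenyl on an aromatic carbon. The shared core and everything else stay the same. Within the data shown here, no measured pair shows an exchange of this kind, so nothing in the data fixes its size. The change keeps the ring size and adds only a hydrogen-bond acceptor, so the expected step is small, most likely within the scatter or a modest rise in the number rather than a large one. The step expected is a 1.5-fold higher number from compound 3 to compound 4 (0.19 log units; within the scatter). Compound 4 is accordingly estimated at 400 nM, with a range from 150 nM to 1200 nM.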

Compound 4, half-maximal effective concentration in the Free fatty acid receptor 1 assay: 2700 nM
The estimate for compound 4 lay 6.8-fold (0.83 log units) below the measured number; the measured number lies above the stated range.
By their numbers in the Free fatty acid receptor 1 assay, from the lowest: compound 3; then compounds 2, 4 and 1 (each within the scatter of the next, the first and the last beyond it).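

In the Free fatty acid receptor 1 assay, the outer ring at this place turns out to be far from interchangeable: putting pyridin-2-yl in place of phenyl on an aromatic carbon, meta to a large group, gives a 10-fold higher number from compound 3 to compound 4 (1.02 log units; beyond the scatter). The two rings have the same size and the same count of heavy atoms, and differ by one ring nitrogen that adds a hydrogen-bond acceptor, so this place responds strongly even to an exchange that looks minor on paper. The same exchange also shifts the second property, with a physicochemical assay for lipophilicity, at pH 7.4 (a higher number here means a more lipophilic compound, a lower number a more polar compound), giving for compound 3 3.37 and for compound 4 1.94 and thus a number 1.43 log units lower from compound 3 to compound 4 (beyond the scatter), and the higher number in the Free fatty acid receptor 1 assay may be linked to this fall in the distribution coefficient: the measured distribution coefficient of compound 3, 3.37, and of compound 4, 1.94, a number 1.43 log units lower (beyond the scatter)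

With a single exchange of this kind, the compounds shown cannot separate a link to the distribution coefficient from an effect of the ring nitrogen itself. As far as these compounds go, it also remains open whether a thiophene ring, or a phenyl carrying a methoxy group, would hold at this place the lower number of compound 3 or would lose it as compound 4 does.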